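The compounds below may be only part of what the source reports. "The series", "measured", "known", "first", "only" and "open" are said of these compounds alone.

Measured so far:
- compound 1, `CCCCCCCCS(=O)(=O)Nc1cc(-c2ccc(Cl)cc2)ccc1C(=O)O`: 18100 nM
- compound 2, `CCCCCCCCS(=O)(=O)Nc1ccc(-c2ccc(CCCC)cc2)cc1C(=O)O`: 9000 nM

In an assay on mitochondria (strain BALB/c) for inhibition of glycerol-3-phosphate acyltransferase 1, mitochondrial (Mus musculus), read by scintillation counting, with a stated time of 10 min (a lower number here means a stronger inhibitor, a higher number a weaker inhibitor), compound 2 gives 9000 nM, and compound 1 gives 18100 nM; these two numbers lie within the usual scatter of each other, so neither stands apart. Compound 3, `CCCCCCCCS(=O)(=O)Nc1ccc(-c2ccc(OC)cc2)cc1C(=O)O`, has not yet been measured. It differs from compound 2 by one change: methoxy in place of butyl on an aromatic carbon. For the measured compounds named here, no measured pair shows what this change does, so there is no basis for expecting a step beyond the scatter in either direction. Compound 3 is therefore expected to give about 12000 nM, between 4000 nM and 40000 nM. That expectation means a step from compound 2 to compound 3 of a 1.3-fold higher number from compound 2 to compound 3 (0.12 log units; within the scatter).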

Compound 3, half-maximal inhibitory concentration: 19500 nM
For compound 3 the middle estimate is 1.6-fold (0.21 log units) below the measured one, within the range that was stated.
By their numbers in this assay, from the lowest: compounds 2, 1 and 3 (each within the scatter of the next, the first and the last beyond it).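

For the compounds shown here, this is the first pair to show what this position does: in this assay, going from 4-butylphenyl to 4-methoxyphenyl gives a 2.2-fold higher number from compound 2 to compound 3 (0.34 log units; beyond the scatter). The group on this aromatic carbon therefore affects the number, modestly, and here the butyl compound has the lower number. No measurement at hand explains the step. With only these two groups, the shorter group and the added oxygen cannot be told apart. A longer chain such as hexyl, or an amine, at this position remains an open case, in either direction.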